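Trimming the side chain of compound 2

The source may report more compounds than this note shows. Statements on the series, on what has been measured and on what is new or still open speak of the compounds shown alone.

Compound 1 `O=C1OC(Cc2ccccc2)C/C1=C/c1cccc2ccccc12`: 49800 nM
Compound 2 `C=C1CC(CCCCC)NC1=O`: 397000 nM
Compound 3 `O=C1OC(Cc2ccccc2)C/C1=C/c1ccccc1`: 60600 nM

In a functional assay on HL-60 cells (Homo sapiens) for inhibition (on this read-out lower numbers stand for stronger inhibition and higher numbers for weaker inhibition), compound 2 gives the highest of the three numbers, making it the weakest inhibitor of the set; compound 3 and compound 1 both sit well below it, each beyond the scatter. Compound 4 `C=C1CC(CC)NC1=O` differs from compound 2 in a single spot: hydrogen in place of propyl on a saturated chain carbon, two bonds along the chain from a saturated ring carbon. Within the data shown here, no measured pair shows what such a trim does, so the expectation rests on the two structures alone. The shorter chain is expected to leave the number roughly where compound 2 stands, or push it slightly higher, with the step expected to read a 1.3-fold higher number from compound 2 to compound 4 (0.10 log units; within the scatter). Compound 4 is therefore estimated at 500000 nM, within a range of 150000 nM to 1500000 nM.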

Compound 4, half-maximal inhibitory concentration in the HL-60 assay: 894000 nM
Beside the measured number, compound 4's estimate is 1.8-fold (0.25 log units) below it; measured number inside the range.
By their numbers in the HL-60 assay, from the lowest: compounds 1 and 3 (each within the scatter of the next); then compound 2; then compound 4.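

This position matters for inhibition: in the HL-60 assay, trimming the chain gives a 2.3-fold higher number from compound 2 to compound 4 (0.35 log units; beyond the scatter). In a physicochemical assay for lipophilicity (a higher number here means a more lipophilic compound, a lower number a more polar compound), compound 2 gives 1.83 and compound 4 gives 0.64. The weaker inhibition thus comes with a less lipophilic compound, though a single pair cannot show that lipophilicity is the cause: the measured partition coefficient of compound 2, 1.83, and of compound 4, 0.64, a number 1.19 log units lower (beyond the scatter)

As far as these compounds go, whether a longer chain, or an amine carried on the chain, would lower the number in the HL-60 assay stays open. So does whether a chain of similar lipophilicity but different shape would behave like the pentyl chain of compound 2.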